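This account rests on a few compounds, and the source may have more. Where it says the series, first, only, none or still open, it means among the compounds named here.

Compound 1 `COc1ccc(C2CC(Nc3nc4ccc(C)cc4s3)=NN2C(C)=O)cc1`: 37.3 umol/kg
Compound 2 `COc1ccc(C2CC(Nc3nc4ccc(C)cc4s3)=NN2C(C)=O)cc1O`: 73.9 umol/kg
Compound 3 `CC(=O)N1N=C(Nc2nc3ccc(C)cc3s2)CC1c1ccccc1`: 106 umol/kg

These values come from a functional assay on the whole organism (Hindlimb, strain albino) with Mus musculus as the target, in the maximal electroshock model, with a stated time of 0.5 h; a higher number here means that more compound is needed for the effect, a lower number that less compound is needed. Compound 2 stands close to both other compounds, with a 2.0-fold higher number from compound 1 to compound 2 (0.30 log units; within the scatter) and a 1.4-fold higher number from compound 2 to compound 3 (0.16 log units; within the scatter). Compound 4 `COc1ccc(C2CC(Nc3nc4ccccc4s3)=NN2C(C)=O)cc1O` differs from compound 2 by hydrogen in place of methyl on an aromatic carbon, which is hydrogen in place of methyl on an aromatic carbon. Going by the values given here, none of the measured steps touches that place. All of them lie elsewhere in the molecule, and the largest is a 2.8-fold higher number from compound 1 to compound 3 (0.45 log units; beyond the scatter), so they offer only a loose guide to size. No change beyond the scatter is therefore expected in this assay, and the expected step is a 1.1-fold higher number from compound 2 to compound 4 (0.03 log units; within the scatter). The estimated value for compound 4 is 80 umol/kg, with an expected range of 35 umol/kg to 180 umol/kg.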

Compound 4, dose for half-maximal effect: 259 umol/kg
Beside the measured number, compound 4's estimate is 3.2-fold (0.51 log units) below it; measured number above the stated range.
By their numbers in this assay, from the lowest: compounds 1, 2 and 3 (each within the scatter of the next, the first and the last beyond it); then compound 4.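

Removing the methyl from the six-membered aromatic ring of the fused system gives a 3.5-fold higher number from compound 2 to compound 4 (0.54 log units; beyond the scatter) in this assay. Going by these compounds alone, this place therefore responds to a change of one carbon, which the earlier steps, all made elsewhere in the molecule, could not show. Nothing available explains this shift.

From the compounds shown here alone, it remains open whether a larger group at this place, such as ethyl, methoxy or chlorine, would lower the number further or raise it. An amine there is equally unresolved, as is whether the methyl has the same effect on the cores of compound 1 and compound 3.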